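The compounds below may be only part of what the source reports. "The series", "measured", "known", "first", "only" and "open" are said of these compounds alone.

Among the compounds with values here, in a functional assay on HepG2 cells (Homo sapiens) for inhibition, read by MTT assay, with a stated time of 72 h (a lower number here means a stronger inhibitor, a higher number a weaker inhibitor), compound 1 (`CC(C)CCN(CCCCCC(=O)NO)c1ncc(C(=O)NCCCn2ccnc2)s1`) gives 106000 nM, the higher of the two numbers measured so far, which makes it the weaker inhibitor of the pair. Compound 2 (`CC(C)CCN(CCCCCCC(=O)NO)c1ncc(C(=O)NCCCn2ccnc2)s1`) gives 24000 nM. Within the data shown here, the only measured step, a 4.4-fold lower number from compound 1 to compound 2 (0.65 log units; beyond the scatter), places (hydroxycarbamoyl)methyl where hydroxycarbamoyl stood, on a saturated chain carbon. Compound 3 (`O=C(CCCCCN(Cc1ccc(F)cc1)c1ncc(C(=O)NCCCn2ccnc2)s1)NO`) leaves that part as it is in compound 1 and changes another place: 4-fluorophenyl in place of isobutyl on a saturated chain carbon bound to a nitrogen on an aromatic ring. In words, 4-fluorophenyl replaces isobutyl on a saturated chain carbon bound to a nitrogen on an aromatic ring, so isopentyl becomes 4-fluorobenzyl. Among the measured compounds shown here, no measured step covers this change, so a 4.4-fold lower number from compound 1 to compound 2 (0.65 log units; beyond the scatter) offers only a rough guide to size and none to direction. A modest move towards a lower number is expected, but this is a tentative judgement. The expected change is a 2.1-fold lower number from compound 1 to compound 3 (0.33 log units; beyond the scatter). For compound 3 the estimated value is 50000 nM, with an expected range of 15000 nM to 150000 nM.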

Compound 3, half-maximal inhibitory concentration: 30000 nM
Compound 3: middle estimate off by 1.7-fold (0.22 log units), on the high side; the measured number falls inside the stated range.
By their numbers in this assay, from the lowest: compounds 2 and 3 (each within the scatter of the next); then compound 1.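

In this assay, putting 4-fluorobenzyl where isopentyl stood gives a 3.5-fold lower number from compound 1 to compound 3 (0.55 log units; beyond the scatter). This shows that the number responds not only to the hydroxycarbamoyl end of the chain but also to the group on the other side of the nitrogen, and that at this place, on a saturated chain carbon bound to a nitrogen on an aromatic ring, a six-membered aromatic ring of carbon only gives a lower number than the open-chain isobutyl. No measurement shown explains this shift.

From the compounds shown here alone, whether a plain benzyl without the fluorine, or a saturated cyclohexylmethyl, would give a similar number remains open. Also open, going by these compounds, is how 4-fluorobenzyl would behave on the longer chain of compound 2.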